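The source may hold more compounds than are shown below. What is called first, only, known or untested is meant among the compounds shown, and "the series" means these compounds.

In a functional assay on U-87MG ATCC cells for inhibition, with U-87 MG (Homo sapiens) as the target, read by MTT assay, with a stated time of 72 h (a lower number here means a stronger inhibitor, a higher number a weaker inhibitor), compound 1 `Cc1noc(C)c1-c1cnc(N)c(Oc2ccc(C(=O)NC3CC3)cc2)n1` gives 43300 nM, compound 2 `Cc1noc(C)c1-c1cnc(N)c(Oc2ccc(C(=O)Nc3ccccc3Cl)cc2)n1` gives 60500 nM, and compound 3 `Cn1cc(-c2cnc(N)c(Oc3ccc(C(=O)Nc4ccccc4Cl)cc3)n2)cn1` gives 44800 nM. Compound 3 stands second highest of the three numbers, although all three lie within the scatter of one another. Compound 4 `Cn1cc(-c2cnc(N)c(Oc3ccc(C(=O)Nc4cccc(Cl)n4)cc3)n2)cn1` differs from compound 3 in a single place: 6-chloropyridin-2-yl in place of 2-chlorophenyl on an amide-type nitrogen. For the measured compounds named here, two measured steps bear on this. Swapping the group on the amide-type nitrogen gave a 1.4-fold higher number from compound 1 to compound 2 (0.15 log units; within the scatter), and swapping the group on the aromatic carbon gave a 1.4-fold lower number from compound 2 to compound 3 (0.13 log units; within the scatter); neither moved the number beyond the scatter. A further swap on the amide-type nitrogen is therefore expected to give a 1.0-fold higher number from compound 3 to compound 4 (0.00 log units; within the scatter), no step beyond the scatter. Compound 4 is estimated at 45000 nM, within a range from 15000 nM to 130000 nM.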

Compound 4, half-maximal inhibitory concentration: 54800 nM
Compound 4: middle estimate off by 1.2-fold (0.09 log units), on the low side; the measured number falls inside the stated range.
By their numbers in this assay, from the lowest: compounds 1, 3, 4 and 2 (each within the scatter of the next).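

In this assay, 6-chloropyridin-2-yl in place of 2-chlorophenyl on the amide-type nitrogen gave a 1.2-fold higher number from compound 3 to compound 4 (0.09 log units; within the scatter), so the hydrogen-bond acceptor counted on the entering group came with no change beyond the scatter. Together with the earlier swap of cyclopropyl for 2-chlorophenyl, this makes two different changes at this nitrogen that stayed within the scatter. No measurement at hand offers an explanation for this result. Still open, from the compounds shown here alone, is whether a plain phenyl, without the chlorine, would behave alike. Also open, going by these compounds, is whether a chain ending in an amine or a carboxylic acid at this nitrogen would move the number beyond the scatter.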